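Moving the Ring Nitrogen in an Isoquinoline Urea

The source may report more compounds than this note shows. Statements on the series, on what has been measured and on what is new or still open speak of the compounds shown alone.

Going by the values given here, compound 2 `CN(C)C1(Cc2ccccc2)CCN(c2cc(C(F)(F)F)ccc2CNC(=O)Nc2ccc3ccncc3c2)CC1` is the stronger of the two compounds measured so far: in an assay on CHO cells for displacement of a labelled ligand from transient receptor potential cation channel subfamily V member 1 (Homo sapiens), read by scintillation counting, with a stated time of 60 min (a higher number here means a weaker inhibitor, a lower number a stronger inhibitor), compound 2 gives 7.33 nM, while compound 1 `CN(C)C1(Cc2ccccc2)CCN(c2cc(C(F)(F)F)ccc2CNC(=O)Nc2cccc3c(=O)[nH]ccc23)CC1` gives 111 nM. The difference between them is the ring system carried by the urea; the step of a 15-fold lower number from compound 1 to compound 2 (1.18 log units; beyond the scatter) shows how much that part of the molecule matters. Compound 3 `CN(C)C1(Cc2ccccc2)CCN(c2cc(C(F)(F)F)ccc2CNC(=O)Nc2cccc3cnccc23)CC1` keeps the same atoms as compound 2 but joins them differently: isoquinolin-5-yl in place of isoquinolin-7-yl on an amide-type nitrogen. Among the compounds with values here, no measured step tests such a shift of the ring nitrogen; the one step available changed the ring system itself, so it only says that this region can move the number a lot. With no guide to direction, the change from compound 2 to compound 3 is expected to stay within the usual scatter, as a 1.4-fold higher number from compound 2 to compound 3 (0.13 log units; within the scatter). Compound 3 is therefore estimated at 10 nM, with a range from 3 nM to 35 nM.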

Compound 3, inhibition constant: 0.67 nM
Compound 3: the middle estimate sits 15-fold (1.17 log units) above what was measured; the whole stated range lies above it.
By their numbers in this assay, from the lowest: compound 3; then compound 2; then compound 1.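

Changing only the point where the isoquinoline joins the urea nitrogen, from isoquinolin-7-yl to isoquinolin-5-yl, gives an 11-fold lower number from compound 2 to compound 3 (1.04 log units; beyond the scatter) in this assay, so the point of attachment alone can produce a large step, even with identical atoms. Set against the larger group carrying an oxygen in compound 1, the isoquinolin-5-yl group gives a wider step still: a 170-fold lower number from compound 1 to compound 3 (2.22 log units; beyond the scatter), which leaves compound 3 with the lowest number of the three. No measurement is available that explains why this change has so large an effect.

The compounds shown leave open whether a methoxy group or an amine on the isoquinolin-5-yl ring would keep so low a number. On these data alone, it also remains open whether a naphthalen-1-yl group, which has no ring nitrogen, could take the place of isoquinolin-5-yl.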